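Moving from a thiophene to a methoxyphenyl group

The source may report more compounds than this note shows. Statements on the series, on what has been measured and on what is new or still open speak of the compounds shown alone.

Compound 1 `COc1ccccc1C(C1=C(O)C(=O)c2ccccc2C1=O)c1c[nH]c2ccccc12`: > 200000 nM (a limit)
Compound 2 `O=C1C(O)=C(C(c2ccc(F)cc2)c2c[nH]c3ccccc23)C(=O)c2ccccc21`: 28100 nM
Compound 3 `O=C1C(O)=C(C(c2cccs2)c2c[nH]c3ccccc23)C(=O)c2ccccc21`: 12100 nM

Three compounds share one core and differ only in the aromatic group on a saturated chain carbon bound to an aromatic carbon and a double-bonded ring carbon. In a functional assay on ECa-109 cells (Homo sapiens) for cytotoxicity, read by MTT assay, with a stated time of 48 h (on this read-out higher numbers stand for weaker inhibition and lower numbers for stronger inhibition), compound 1 reaches only (the limit of > 200000 nM in this assay, at which 1 of the 3 values shown sits), so no number is known for it. Compound 3 gives the lowest of the two numbers shown, and its nearest neighbour is compound 2, with a 2.3-fold lower number from compound 2 to compound 3 (0.37 log units; beyond the scatter). Compound 4 `COc1cccc(C(C2=C(O)C(=O)c3ccccc3C2=O)c2c[nH]c3ccccc23)c1` carries the change (3-methoxyphenyl in place of thiophen-2-yl on a saturated chain carbon bound to an aromatic carbon and a double-bonded ring carbon).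

Within the data shown here, two measured steps bear on this. The step of an at least 16-fold lower number from compound 1 to compound 3 (1.21 log units; beyond the scatter) shows that replacing a methoxyphenyl by the thiophene lowered the number sharply; the step of a 2.3-fold lower number from compound 2 to compound 3 (0.37 log units; beyond the scatter) shows the same direction for a six-membered carbon ring. Reversing that direction, compound 4 is expected to give a higher number than compound 3, by about a 3.7-fold higher number from compound 3 to compound 4 (0.57 log units; beyond the scatter). The estimate for compound 4 is 45000 nM, with a range from 12000 nM to 200000 nM.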

Compound 4, half-maximal inhibitory concentration: 40000 nM
For compound 4 the middle estimate is 1.1-fold (0.05 log units) above the measured one; the measured number falls inside the stated range.
By their numbers in this assay, from the lowest: compound 3; then compounds 2 and 4 (each within the scatter of the next). At a limit, above all of these: compound 1.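

In this assay, the outcome at this place depends on which methoxyphenyl group is carried, not simply on having one: 3-methoxyphenyl in place of 2-methoxyphenyl gives an at least 5.0-fold lower number from compound 1 to compound 4 (0.69 log units; beyond the scatter). Compound 1 remains a limit, not a number: the limit of > 200000 nM in this assay, at which 1 of the 4 values shown sits. The thiophen-2-yl group of compound 3 still gives the lower number against 3-methoxyphenyl, with a 3.3-fold higher number from compound 3 to compound 4 (0.52 log units; beyond the scatter), while 3-methoxyphenyl and 4-fluorophenyl cannot be told apart, with a 1.4-fold higher number from compound 2 to compound 4 (0.15 log units; within the scatter).

The compounds shown leave open how a 4-methoxyphenyl group would compare with the 2-methoxyphenyl and 3-methoxyphenyl groups at this place. They also leave open whether another five-membered aromatic ring, such as furan-2-yl, or a phenyl ring carrying an amine or a carboxylic acid, would give a number as low as that of compound 3.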